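A few compounds are considered here, and "the series" means these few. Any claim that something is new, unique, unknown or untested is made for them only; others in the source may bear on it.

Of the compounds shown here, three sharing one core have been tested in an assay on isolated protein for inhibition of Maltase-glucoamylase (Homo sapiens), with a stated time of 15 min; a higher number here means a weaker inhibitor, a lower number a stronger inhibitor. Compound 1 `O=C(N/N=C/c1cccnc1)c1ccc(-c2nc3ccccc3s2)cc1` bears a pyridin-3-yl group on a carbon with a double bond to nitrogen, and in this assay compound 1 gives "not active" (no number reported). Compound 2 `O=C(N/N=C/c1ccc(O)cc1O)c1ccc(-c2nc3ccccc3s2)cc1` carries a 2,4-dihydroxyphenyl group at that position, and compound 2 gives 5580 nM. Compound 3 `O=C(N/N=C/c1ccccc1)c1ccc(-c2nc3ccccc3s2)cc1` carries a plain phenyl there, and compound 3 gives 8050 nM. Among the two reported numbers compound 3 has the higher one, yet the step of a 1.4-fold higher number from compound 2 to compound 3 (0.16 log units; within the scatter) lies within the scatter, so no real difference between compound 2 and compound 3 can be claimed.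

Compound 4 `O=C(N/N=C/c1ccncc1)c1ccc(-c2nc3ccccc3s2)cc1` is the next step from compound 3: pyridin-4-yl in place of phenyl on a carbon with a double bond to nitrogen. For the measured compounds named here, no measured step swaps phenyl for a pyridinyl group, so the step from compound 2 to compound 3 does not bear directly on it. Going by the values given here, the only hint comes from compound 1, whose pyridin-3-yl analogue is recorded as inactive in this assay. That single result suggests a move toward a higher number, though no size can be read from it. The step of a 2.5-fold higher number from compound 3 to compound 4 (0.40 log units; beyond the scatter) is therefore the expectation, with a real chance that no number is reported at all. Compound 4 is estimated at 20000 nM, within a range from 6000 nM to 80000 nM.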

Compound 4, half-maximal inhibitory concentration: "not active" (no number reported)
Nothing numeric was reported for compound 4, so the estimate cannot be set against anything.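

In this assay, for the compounds shown here, compound 4 gives "not active" (no number reported) and so, with no number to set against compound 3, no step between these two compounds can be read. No measured evidence explains this result. The compounds shown leave open how much weaker compound 1 and compound 4 are than compound 3, and whether any pyridinyl compound on this core yields a number.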